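The source may hold more compounds than are shown below. What is called first, only, known or untested is meant among the compounds shown, and "the series" means these compounds.

Measured so far in a functional assay on the whole organism (strain Wistar) with Rattus norvegicus as the target, with a stated time of 5 min; on this read-out lower numbers stand for an effect already at smaller amounts and higher numbers for an effect only at larger amounts of compound:
- compound 1 `CCC1(CCCCN2CCN(c3ccc(Cl)c(Cl)c3)CC2)C(=O)Nc2ccccc21`: > 20 mg/kg, a limit of the assay, not a number
- compound 2 `CCC1(CCCCN2CCN(c3ccc(F)c(Cl)c3)CC2)C(=O)Nc2ccccc21`: > 20 mg/kg, likewise a limit
- compound 3 `CCC1(CCCCN2CCN(c3ccc(OC)cc3)CC2)C(=O)Nc2ccccc21`: > 20 mg/kg, likewise a limit

Compound 3 stands at the limit of this assay, and this is all that is known of it. The two compounds beside it stand at the same limit, so the steps a step that the two limits leave unreadable from compound 1 to compound 2, a step that the two limits leave unreadable from compound 1 to compound 3 and a step that the two limits leave unreadable from compound 2 to compound 3 give no readable size and no direction; the one thing the measured set shows is the limit of > 20 mg/kg in this assay, at which 3 of the 3 values shown sit.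

Compound 4 `CCC1(CCCCN2CCN(c3ccc(Cl)cc3)CC2)C(=O)Nc2ccccc21` differs from compound 3 by chloro in place of methoxy on an aromatic carbon. Among the compounds with values here, no measured step in this assay bears on this change, since every value on record is a limit. With nothing pointing either way, no step beyond the scatter is expected in this assay; the estimated step that the limit leaves unreadable from compound 3 to compound 4 is meant as no change. Compound 4 is therefore expected at 30 mg/kg, within 12 mg/kg to 80 mg/kg, with a strong chance that only a limit is again reported.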

Compound 4, minimum effective dose: 10 mg/kg
For compound 4 the middle estimate is 3.0-fold (0.48 log units) above the measured one; measured number outside the range, below it.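

In this assay, compound 4 is the only member shown with a number rather than a limit, so the group on the amine nitrogen in a ring can move this read-out off the limit: the limit of > 20 mg/kg in this assay, at which 3 of the 4 values shown sit. Chloro in place of methoxy gives an at least 2.0-fold lower number from compound 3 to compound 4 (0.30 log units; that floor lies within the scatter), hydrogen in place of chloro gives an at least 2.0-fold lower number from compound 1 to compound 4 (0.30 log units; that floor lies within the scatter), and 4-chlorophenyl in place of 3-chloro-4-fluorophenyl gives an at least 2.0-fold lower number from compound 2 to compound 4 (0.30 log units; that floor lies within the scatter). Each step is only a floor, and compounds 1 and 2 also carry chloro yet stay at the limit, so chloro alone does not account for the number in compound 4.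

The steps among compounds 1, 2 and 3 cannot be read. From the compounds shown here alone, whether fluoro, methyl or trifluoromethyl at the same place, or a shorter or longer chain to the core, would keep or shift the number remains open.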